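The compounds below may be only part of what the source reports. "The series", "measured", "known", "first", "only" and "open" are said of these compounds alone.

In an assay on isolated protein for binding affinity to corticotropin-releasing factor receptor 1 (Homo sapiens) (a lower number here means a stronger inhibitor, a higher number a weaker inhibitor), compound 1, whose structure is `CCN(Cc1ccccc1)c1cc(C)nc(N(CC)c2ccc(C(C)C)cc2Br)n1`, gives 17 nM. Among the three measured compounds it stands second highest: compound 2 `CCCCN(CC#N)c1nc(C)nc(N(CC)c2ccc(N(C)C)cc2C(F)(F)F)n1` gives 6 nM, a lower number by a gap that lies beyond the scatter, while compound 3 `CCN(c1nc(C)cc(C)n1)c1ccc(OC)cc1SC` gives 60 nM, a higher number by a gap that also lies beyond the scatter. Compound 4 `CCC(CC)c1cc(C)nc(N(CC)c2ccc(C(C)C)cc2Br)n1` has not yet been measured in this assay. It differs from compound 1 in one place: pentan-3-yl in place of benzyl(ethyl)amino on an aromatic carbon. For the measured compounds named here, no step between two measured compounds covers this change, so the account expects the step from compound 1 to compound 4 to be small and towards a lower number, at the edge of the scatter, as a 1.4-fold lower number from compound 1 to compound 4 (0.15 log units; within the scatter). Compound 4 is therefore estimated to give 12 nM, with a range from 4 nM to 40 nM.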

Compound 4, inhibition constant: 2 nM
Estimate against measurement, compound 4: 6.0-fold (0.78 log units) above; the whole stated range lies above it.
By their numbers in this assay, from the lowest: compound 4; then compound 2; then compound 1; then compound 3.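

Replacing benzyl(ethyl)amino with pentan-3-yl on this aromatic carbon gives an 8.5-fold lower number from compound 1 to compound 4 (0.93 log units; beyond the scatter) in this assay, a step beyond the scatter. The pair shows that a low number at this position requires neither the carbon aromatic ring nor the nitrogen of the departing group, for the group that enters has no ring and no hydrogen-bond acceptor. No measurement here accounts for the size of this step. Going by these compounds, the two features leave together, so which of them matters stays open. So does whether a diethylamino group or a cyclopentyl ring at this position would give a similarly low number.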